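Cyclohexyl in Place of 4-Methylphenyl on the Amine Nitrogen

The source may report more compounds than this note shows. Statements on the series, on what has been measured and on what is new or still open speak of the compounds shown alone.

Compound 1, `O=c1cc(NC2CC2)cc(-c2ccccc2)o1`: > 30 uM
Compound 2, `Cc1ccc(Nc2cc(-c3ccccc3)oc(=O)c2)cc1`: 0.067 uM

Among the compounds with values here, in a functional assay on A549 cells (Homo sapiens) for cytotoxicity, read by MTT assay, with a stated time of 72 h (on this read-out lower numbers stand for an effect already at smaller amounts and higher numbers for an effect only at larger amounts of compound), compound 2 gives 0.067 uM, the only plain number among the two entries. For compound 1 the assay reports only the limit > 30 uM, as noted in the limit of > 30 uM in this assay, at which 1 of the 2 values shown sits. Within the data shown here, the one measured step, an at least 440-fold lower number from compound 1 to compound 2 (2.65 log units; beyond the scatter), is large and beyond the scatter.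

Compound 3, `O=c1cc(NC2CCCCC2)cc(-c2ccccc2)o1`, is not yet measured. It differs from compound 2 by cyclohexyl in place of 4-methylphenyl on a nitrogen on an aromatic ring. This change walks back from the aromatic ring toward an aliphatic ring on the same nitrogen, the kind of ring that compound 1 carries, so the step of compound 1 to compound 2 bears on it in reverse, and a large rise in the number beyond the scatter is expected, as a 120-fold higher number from compound 2 to compound 3 (2.08 log units; beyond the scatter). Compound 3 is therefore estimated at 8 uM, within a range from 0.8 uM to 40 uM.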

Compound 3, concentration for half-maximal effect: 9.69 uM
Beside the measured number, compound 3's estimate is 1.2-fold (0.08 log units) below it; low and high end bracket the measured number.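

On this nitrogen, this assay shows a 140-fold higher number from compound 2 to compound 3 (2.16 log units; beyond the scatter) for cyclohexyl in place of 4-methylphenyl, so a six-membered ring of carbon alone does not carry the low number of compound 2, and the aromatic and non-aromatic rings stand far apart here. The non-aromatic rings also differ from each other, with an at least 3.0-fold lower number from compound 1 to compound 3 (0.49 log units; beyond the scatter) for cyclohexyl in place of cyclopropyl, a step beyond the scatter. That step gives only a bound, since compound 1 is known by a limit and not by a number: the limit of > 30 uM in this assay, at which 1 of the 3 values shown sits.

From the compounds shown here alone, whether the low number of compound 2 rests on the aromatic ring or on its methyl stays open, as does the standing of plain phenyl or 4-chlorophenyl on this nitrogen. Going by these compounds, it is also open how a piperidinyl ring or an open chain such as n-hexyl would compare with cyclohexyl.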